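Replacing the urea amino group with a hydroxycarbamoyl group

The source may hold more compounds than are shown below. What is called first, only, known or untested is meant among the compounds shown, and "the series" means these compounds.

The three measured compounds share a core carrying an amide to a bis(trifluoromethyl)benzyl group, and differ in the substituent on the ring nitrogen and on the aryl ring. Compound 1 `CC(=O)N1CC[C@H](C(=O)N(C)Cc2cc(C(F)(F)F)cc(C(F)(F)F)c2)[C@H](c2ccccc2)C1` gives 3.2 nM in an assay on IM-9 cells for displacement of a labelled ligand from Substance-P receptor (Homo sapiens), read by scintillation counting, with a stated time of 30 min; a lower number here means a stronger inhibitor, a higher number a weaker inhibitor. Compound 2 `CC(=O)NCC(=O)N1CC[C@H](C(=O)N(C)Cc2cc(C(F)(F)F)cc(C(F)(F)F)c2)[C@@H](c2ccc(F)cc2C)C1` gives 0.043 nM in this assay. Compound 3 `Cc1cc(F)ccc1[C@H]1CN(C(N)=O)CC[C@@H]1C(=O)N(C)Cc1cc(C(F)(F)F)cc(C(F)(F)F)c1` gives 0.035 nM, the lowest number of the three, with compound 2 close to it and compound 1 far off. Within the data shown here, the one single-point step available, a 1.2-fold lower number from compound 2 to compound 3 (0.09 log units; within the scatter), shows that exchanging the group on the carbonyl carbon attached to the ring nitrogen changes little.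

Compound 4 `Cc1cc(F)ccc1[C@H]1CN(C(=O)C(=O)NO)CC[C@@H]1C(=O)N(C)Cc1cc(C(F)(F)F)cc(C(F)(F)F)c1` carries the change (hydroxycarbamoyl in place of amino on a carbonyl carbon), so that the carbamoyl on the ring nitrogen becomes a (hydroxycarbamoyl)carbonyl. Among the measured compounds shown here, only the step from compound 2 to compound 3 bears on this, and it lay within the scatter, so the number for compound 4 is expected to stay close to that of compound 3, with the estimated step of a 2.0-fold higher number from compound 3 to compound 4 (0.30 log units; within the scatter) carrying some risk of a weaker result. For compound 4 the estimate in this assay is 0.07 nM, within a range from 0.02 nM to 0.4 nM.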

Compound 4, half-maximal inhibitory concentration: 0.046 nM
Compound 4: middle estimate off by 1.5-fold (0.18 log units), on the high side, within the range that was stated.
By their numbers in this assay, from the lowest: compounds 3, 2 and 4 (each within the scatter of the next); then compound 1.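

The exchange from carbamoyl to (hydroxycarbamoyl)carbonyl on the ring nitrogen gives, in this assay, a 1.3-fold higher number from compound 3 to compound 4 (0.12 log units; within the scatter) and so shows that this position takes a hydroxycarbamoyl group, with its 4 heavy atoms, in place of amino without the number leaving the scatter. Set against the acetamidomethyl group, the same group gives a 1.1-fold higher number from compound 2 to compound 4 (0.03 log units; within the scatter), so that amino, acetamidomethyl and hydroxycarbamoyl, all on a carbonyl carbon whose other neighbour is an amide-type nitrogen in a ring, cannot be told apart in these data, which extends the earlier single step to a third group with a hydroxylamine-derived end. Nothing available offers an explanation for this sameness of the numbers.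

Still open, on these data alone, is whether the same flat picture would hold for a group of a different kind on this carbonyl carbon, such as a carboxylic acid, a primary amine or a longer chain ending in an amine. Also open, as far as these compounds go, is whether the hydroxycarbamoyl group would give a similar number on the core of compound 1, with its different aryl group.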